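A few compounds are considered here, and "the series" means these few. Any claim that something is new, unique, unknown or untested is made for them only; others in the source may bear on it.

Compound 3 `CC(C)n1ncc2c(C(=O)NCc3cn(-c4ccc([N+](=O)[O-])cc4)nn3)cccc21` sits at a limit in a functional assay on MGC-803 cells (Homo sapiens) for inhibition, read by MTT assay, with a stated time of 72 h; a higher number here means a weaker inhibitor, a lower number a stronger inhibitor: compound 3 gives > 40000 nM, which is a limit of the assay and not a number. Compound 1 `Cc1ccc(-n2cc(CNC(=O)c3cccc4c3cnn4C(C)C)nn2)cc1C` gives > 40000 nM, also a limit. Compound 2 `CC(C)n1ncc2c(C(=O)NCc3cn(-c4ccc(F)cc4)nn3)cccc21` gives > 40000 nM, again a limit. Compound 4 `Cc1ccc(-n2cc(CNC(=O)c3cccc4c3cnn4C(C)C)nn2)cc1` differs from compound 3 by methyl in place of nitro on an aromatic carbon. For the measured compounds named here, the steps that bear on this change are a step that the two limits leave unreadable from compound 1 to compound 2, a step that the two limits leave unreadable from compound 1 to compound 3 and a step that the two limits leave unreadable from compound 2 to compound 3, none of which can be read, since (the limit of > 40000 nM in this assay, at which 3 of the 3 values shown sit). With every aryl group tried so far resting at that limit, compound 4 is expected to give 45000 nM, between 20000 nM and 100000 nM. The step that the limit leaves unreadable from compound 3 to compound 4 is therefore estimated to stay within the scatter, with another limit the likeliest report.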

Compound 4, half-maximal inhibitory concentration: > 40000 nM
Compound 4: no number, only a limit; the forecaster's own chance of this, stated with the estimate: 80%; the middle value lies beyond the limit too.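

For the compounds shown here, compound 4 also gives only a limit, so no step between it and compound 1, compound 2 or compound 3 can be read: the limit of > 40000 nM in this assay, at which 4 of the 4 values shown sit. The compounds shown leave open which aryl group, if any, would give a measurable value.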